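Swapping Dichlorophenyl for Methylphenyl on the Ether Arm

The source may report more compounds than this note shows. Statements on the series, on what has been measured and on what is new or still open speak of the compounds shown alone.

Three analogues of one shared core have been measured in an assay on isolated protein for inhibition of Dihydrofolate reductase (Homo sapiens), read by spectrophotometry, using NADPH, with stated times of 5 s and 6 min, tested at 5 uM; on this read-out higher numbers stand for a stronger effect at the one concentration tested and lower numbers for a weaker effect. Compound 1 `NC1=NC2(CCOCC2)N(OCCCOc2ccc(Cl)cc2)C(N)=N1` reaches a limit of this assay, reported as > 90%. Compound 2 `NC1=NC2(CCOCC2)N(OCCCOc2cccc(Cl)c2Cl)C(N)=N1` gives 81.7% in this assay. Compound 3 `NC1=NC2(CCOCC2)N(OCCCOc2ccc(Cl)cc2Cl)C(N)=N1` likewise sits at a limit of this assay, reported as > 90%. That limit, (the limit of > 90% in this assay, at which 2 of the 3 values shown sit), leaves the step from compound 1 to compound 3 unreadable: a step that the two limits leave unreadable from compound 1 to compound 3. The step from compound 2 to compound 3 is a number at least 8.3 percentage points higher from compound 2 to compound 3 (that floor lies within the scatter), and the step from compound 1 to compound 2 is a number at least 8.3 percentage points lower from compound 1 to compound 2 (that floor lies within the scatter); both floors lie within the scatter. Compound 4 `Cc1ccc(OCCCON2C(N)=NC(N)=NC23CCOCC3)cc1` differs from compound 3 in one place: 4-methylphenyl in place of 2,4-dichlorophenyl on an oxygen on a saturated carbon. Among the measured compounds shown here, no measured step removes both chlorines or brings in a methyl, so none bears directly on this change; the measured steps show only that rearranging the chlorine pattern shifts the read-out by little, if at all. The account therefore expects a modest fall, a number at least 12 percentage points lower from compound 3 to compound 4 (beyond the scatter), and estimates compound 4 at 78% with a range from 55% to 92%.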

Compound 4, a percentage reported as inhibition, at one concentration (the size of the read-out at that concentration, not a potency): > 90%
Compound 4 was reported as a limit; the forecaster's own chance of this, stated with the estimate: 30%; middle value at least 12 percentage points away from the limit.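

In this assay compound 4 sits at a limit of the assay, > 90%, which shows that at this place a 4-methylphenyl with no chlorine at all still reaches that limit. Among the compounds shown here, the one new step that can be read is a number at least 8.3 percentage points higher from compound 2 to compound 4 (that floor lies within the scatter). The steps from compound 3 and from compound 1 to compound 4 cannot be read, and the read-out no longer separates these compounds: the limit of > 90% in this assay, at which 3 of the 4 values shown sit.

On these data alone, whether compound 4 truly differs from compound 1 or compound 3 remains open at this single concentration. Also open, as far as these compounds go, is how the read-out would respond to a methoxy group, an amine or a carboxylic acid in place of the methyl, or to a longer chain on the ether arm.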